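The compounds below may be only part of what the source reports. "The series", "measured", "known", "first", "only" and "open" are said of these compounds alone.

Values in a functional assay on SMMC-7721 cells (Homo sapiens) for cytotoxicity, read by MTT assay, with a stated time of 72 h (on this read-out higher numbers stand for weaker inhibition and lower numbers for stronger inhibition), for the measured compounds

- compound 1 `CCC(C)=C1C(=O)N(c2ccc(Cl)cc2)N(c2ccc(Cl)cc2)C1=O` gives 49200 nM
- compound 2 `O=C1C(=Cc2ccc(Br)cc2)C(=O)N(c2ccc(Cl)cc2)N1c1ccc(Cl)cc1` gives 16600 nM
- compound 3 `CC(=C1C(=O)N(c2ccc(Cl)cc2)N(c2ccc(Cl)cc2)C1=O)c1ccc(O)cc1` gives 57000 nM

Compound 2 has the lowest number of the three, with compound 1 and compound 3 both higher. Next in line is compound 4 `COc1cccc(C=C2C(=O)N(c3ccc(Cl)cc3)N(c3ccc(Cl)cc3)C2=O)c1OC`, not yet measured. Its difference from compound 2 is 2,3-dimethoxyphenyl in place of 4-bromophenyl on a double-bonded chain carbon bound to a double-bonded ring carbon.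

Within the data shown here, the only measured step is a 1.2-fold higher number from compound 1 to compound 3 (0.06 log units; within the scatter) and it bears on this change only loosely. Among the measured compounds shown here, it concerns a double-bonded chain carbon that also holds a saturated chain carbon, and no measured step exchanges one phenyl group for another on the chain of compound 2. With so little to go on, no step beyond the scatter is expected in this assay, with a slight lean toward the higher numbers of compound 1 (49200 nM) rather than a further fall.

The expected step is a 1.3-fold higher number from compound 2 to compound 4 (0.12 log units; within the scatter) and it remains an estimate. The estimate for compound 4 is 22000 nM with 9000 nM to 50000 nM as the expected range.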

Compound 4, half-maximal inhibitory concentration: 14100 nM
Estimate against measurement, compound 4: 1.6-fold (0.19 log units) above, and the stated range covers the measured number.
By their numbers in this assay, from the lowest: compounds 4 and 2 (each within the scatter of the next); then compounds 1 and 3 (each within the scatter of the next).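

Working notes on the series: in this assay, exchanging 4-bromophenyl for 2,3-dimethoxyphenyl on a double-bonded chain carbon bound to a double-bonded ring carbon gives a 1.2-fold lower number from compound 2 to compound 4 (0.07 log units; within the scatter). Among these compounds, this is the first exchange of one substituted phenyl for another at this position, and the number holds even though bromine leaves and the entering group brings 2 hydrogen-bond acceptors and 10 heavy atoms against 7. No supporting measurement bears on why the number holds across this exchange.

Open, on these data alone, is whether a phenyl carrying an amine or a carboxylic acid at this position would move the number in this assay beyond the scatter. Also open, as far as these compounds go, is whether a single methoxy group would behave as 2,3-dimethoxyphenyl does here.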